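Benzyl to tert-butoxycarbonyl exchange on the bridged ring amine

The compounds below may be only part of what the source reports. "The series", "measured", "known", "first", "only" and "open" are said of these compounds alone.

Three compounds of this series have been run in a functional assay on HEK293 cells for agonist activity at Glucose-dependent insulinotropic receptor (Homo sapiens), read by cAMP accumulation, with a stated time of 60 min; on this read-out lower numbers stand for smaller maximal responses and higher numbers for larger maximal responses. Compound 1 `COc1cc2nc(Nc3ccc(S(C)(=O)=O)cc3)nc(N3CCC4CCC(C3)N4Cc3ccccc3)c2cc1OC` gives 32.8% in this assay. Compound 3 `COc1cc2nc(N3CCC4CCC(C3)N4Cc3ccccc3)nc(Nc3ccc(S(C)(=O)=O)cc3F)c2cc1OC` gives 44.3%, and compound 2 `COc1cc2nc(N3CCC4CCC(C3)N4C(=O)OC(C)(C)C)nc(Nc3ccc(S(C)(=O)=O)cc3F)c2cc1OC` gives 56.9%. Compound 1 therefore stands lowest of the three in this assay, and its gaps to compound 3 and to compound 2 are both beyond the scatter.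

Compounds 3 and 2 differ in one place: tert-butoxycarbonyl in place of benzyl on an amine nitrogen in a ring This change gave a number 12.6 percentage points higher from compound 3 to compound 2 (beyond the scatter), a modest gain in the maximal response. The difference between the core of compound 1 and the core of compound 3 is not broken down here.

Compound 4 `COc1cc2nc(Nc3ccc(S(C)(=O)=O)cc3)nc(N3CCC4CCC(C3)N4C(=O)OC(C)(C)C)c2cc1OC` has not yet been measured in this assay. It arises from compound 1 by the same change: tert-butoxycarbonyl in place of benzyl on an amine nitrogen in a ring The place of the change is described in the same words for both pairs, so the two changes are taken as the same change, made on two different cores.

Among the measured compounds shown here, only one measured instance of the change exists, so any expectation for compound 4 rests on that single step. Compound 4 is expected to reach about 45% in this assay, with a likely span from 35% to 56%. This estimate means a step of a number 12.2 percentage points higher from compound 1 to compound 4 (beyond the scatter), set beside the measured step, and it rests on the gain seen in a number 12.6 percentage points higher from compound 3 to compound 2 (beyond the scatter) being carried over onto the core of compound 1.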

Compound 4, largest response reached (Emax), in percent of the reference or control that the assay uses: 37.5%
For compound 4 the middle estimate is 7.5 percentage points above the measured one; the range from low to high includes it.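

On the core of compound 1, tert-butoxycarbonyl in place of benzyl gives a number 4.7 percentage points higher from compound 1 to compound 4 (within the scatter) in this assay, so no change in maximal response can be claimed for this pair taken alone. Set beside the step on the other core, this result gives no ground for saying that the two cores respond differently: the same change on two cores in this assay, a number 12.6 percentage points higher (beyond the scatter) from compound 3 to compound 2 and a number 4.7 percentage points higher (within the scatter) from compound 1 to compound 4, 7.9 percentage points apart, within the scatter of two such steps The two pairs therefore fit a single shared effect of the exchange, but they do not establish one, as only one of the two steps lies beyond the scatter, two pairs are a thin base, and the result does not show that the exchange gives a real gain on every core of this series.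

The compounds shown leave open how the maximal response follows other groups on the same ring nitrogen, such as the free secondary amine, an acetyl amide or a methylsulfonyl group, all of which would show whether the read-out tracks anything beyond the two groups compared here. Also open, from the compounds shown here alone, is whether a benzyl ring carrying a substituent, or a pyridylmethyl group, would sit closer to compound 1 or to compound 4 on this read-out.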